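Thiophene for Phenyl on Two Inactive Nucleosides

This account rests on a few compounds, and the source may have more. Where it says the series, first, only, none or still open, it means among the compounds named here.

Compound 1 `COc1nc(N)nc2c1c(-c1ccccc1)cn2[C@@H]1O[C@H](CO)[C@@H](O)[C@H]1O` and compound 2 `COc1nc(N)nc2c1c(-c1ccsc1)cn2[C@@H]1O[C@H](CO)[C@@H](O)[C@H]1O` share one core and differ by thiophen-3-yl in place of phenyl on an aromatic carbon. In a functional assay on HCT-116 cells (Homo sapiens), read by MTT assay, with a stated time of 72 h (a higher number here means a weaker inhibitor, a lower number a stronger inhibitor), compound 1 gives only the assay limit of > 20000 nM. In this assay compound 2 likewise gives only the limit of > 20000 nM. The step that the two limits leave unreadable from compound 1 to compound 2 therefore cannot be read, because of the limit of > 20000 nM in this assay, at which 3 of the 3 values shown sit.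

Compound 3 `Nc1nc2c(c(-c3ccccc3)cn2[C@@H]2O[C@H](CO)[C@@H](O)[C@H]2O)c(=O)[nH]1` carries a second core; the difference between the two cores is not broken down here. In this assay compound 3 gives only the limit of > 20000 nM.

Compound 4 `Nc1nc2c(c(-c3ccsc3)cn2[C@@H]2O[C@H](CO)[C@@H](O)[C@H]2O)c(=O)[nH]1`, not yet measured, differs from compound 3 by thiophen-3-yl in place of phenyl on an aromatic carbon. This is the same kind of change as that from compound 1 to compound 2; around the place, the ring atom is described once as bearing a 3,4-dihydroxy-5-(hydroxymethyl)oxolan-2-yl group and once as bearing a group of 9 heavy atoms.

The step from compound 3 to compound 4 in this assay is expected to be a step that the limit leaves unreadable from compound 3 to compound 4, an estimate resting on compound 1 and compound 2 both sitting at the limit (the limit of > 20000 nM in this assay, at which 3 of the 3 values shown sit). Compound 4 is accordingly estimated at 30000 nM, most likely reported again as a limit.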

Compound 4, half-maximal inhibitory concentration: > 20000 nM
Compound 4: a limit, no number; the forecaster's own chance of this, stated with the estimate: 85%; the middle value does not contradict the limit.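

In this assay compound 4 gives > 20000 nM, which is a limit and not a number. The change from compound 3 to compound 4 therefore cannot be sized, because both compounds sit at the same limit: the limit of > 20000 nM in this assay, at which 4 of the 4 values shown sit.

The compounds shown leave open how strongly any of the four inhibits, and whether phenyl or thiophen-3-yl gives the stronger inhibitor on either core.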